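Moving the bromine on the benzyl ether

A few compounds are considered here, and "the series" means these few. Any claim that something is new, unique, unknown or untested is made for them only; others in the source may bear on it.

Within the data shown here, in a functional assay on U-251 cells (Homo sapiens) for antiproliferative activity, read by MTT assay, with a stated time of 24 h (on this read-out higher numbers stand for weaker inhibition and lower numbers for stronger inhibition), compound 3 `COc1cc(OC)c(-c2coc3cc(OCc4ccc(Br)cc4)ccc3c2=O)cc1OC` gives 10000 nM, the highest of the three numbers so far. Compound 1 `C=CCOc1ccc2c(=O)c(-c3cc(OC)c(OC)cc3OC)coc2c1` gives 5900 nM and compound 2 `COc1cc(OC)c(-c2coc3cc(OCc4ccccc4F)ccc3c2=O)cc1OC` gives 2890 nM. The step of a 1.7-fold higher number from compound 1 to compound 3 (0.23 log units; within the scatter) lies within the scatter, whereas a 3.5-fold higher number from compound 2 to compound 3 (0.54 log units; beyond the scatter) lies beyond it, and a 2.0-fold lower number from compound 1 to compound 2 (0.31 log units; beyond the scatter) points the same way: the 2-fluorophenyl ether sits at the low end of the numbers.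

Compound 4 `COc1cc(OC)c(-c2coc3cc(OCc4ccccc4Br)ccc3c2=O)cc1OC` differs from compound 3 in one place: 2-bromophenyl in place of 4-bromophenyl on a saturated chain carbon bound to an oxygen on an aromatic ring. Among the measured compounds shown here, the only measured step that bears on this change is a 3.5-fold higher number from compound 2 to compound 3 (0.54 log units; beyond the scatter), which set 2-fluorophenyl against 4-bromophenyl; no measured pair separates the position of bromine alone, and no step compares two bromophenyl groups. For the measured compounds named here, the 2-fluorophenyl compound gave a lower number than the 4-bromophenyl compound, so a modest step downward is expected for compound 4, a 2.5-fold lower number from compound 3 to compound 4 (0.40 log units; beyond the scatter), with the single supporting step leaving the size uncertain. Compound 4 is estimated at 4000 nM in this assay, range 1500 nM to 10000 nM.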

Compound 4, half-maximal inhibitory concentration: > 10000 nM
Compound 4: only a limit was reported (the forecaster's own chance of this, stated with the estimate: 10%); middle value at least 2.5-fold (0.39 log units) from the limit.
By their numbers in this assay, from the lowest: compound 2; then compounds 1 and 3 (each within the scatter of the next).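

In this assay compound 4 stands at a limit of the assay, not a number: the limit of > 10000 nM in this assay, at which 1 of the 4 values shown sits. Bromo in place of fluoro on an aromatic carbon gives an at least 3.4-fold higher number from compound 2 to compound 4 (0.53 log units; beyond the scatter), so the low number of the 2-fluorophenyl ether does not carry over to the 2-bromophenyl ether. Replacing vinyl with 2-bromophenyl gives an at least 1.6-fold higher number from compound 1 to compound 4 (0.22 log units; that floor lies within the scatter), a floor that does not separate the two compounds. With 2-bromophenyl in place of 4-bromophenyl the data give a number no lower from compound 3 to compound 4 (the limit leaves the size open).

As far as these compounds go, how far 2-bromophenyl and 4-bromophenyl stand apart therefore remains open. Also open, from the compounds shown here alone, is how 4-fluorophenyl, unsubstituted phenyl or 2-chlorophenyl at this place would compare, which would show whether the fluorine or its position sets compound 2 apart.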